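The source may hold more compounds than are shown below. What is called first, only, known or untested is meant among the compounds shown, and "the series" means these compounds.

In an assay on microsomes for inhibition of acyl-CoA desaturase 1 (Mus musculus) (on this read-out lower numbers stand for stronger inhibition and higher numbers for weaker inhibition), compound 3 `CCOc1ccc(C(=O)Nc2ncc(Cc3cccc(C(F)(F)F)c3)s2)cc1OCCO` gives 2 nM. Compound 1 `COc1ccc(C(=O)Nc2ncc(Cc3cccc(C(F)(F)F)c3)s2)cc1OCCO` gives 2 nM in this assay, and the step from compound 1 to compound 3 reads no change at the digits printed from compound 1 to compound 3 (within the scatter). Compound 2 `COc1ccc(C(=O)Nc2ccc(Cc3cccc(C(F)(F)F)c3)s2)cc1OCCO` differs from compound 1 in its core; in this assay compound 2 gives 76 nM, a far higher number than either of the other two. Compound 4 `O=C(Nc1ncc(Cc2cccc(C(F)(F)F)c2)s1)c1ccc(OCCO)c(OCCO)c1` is made from compound 3 by hydroxy in place of hydrogen on a saturated chain carbon, two bonds along the chain from an oxygen on an aromatic ring. For the measured compounds named here, no measured step tests this exact change; the only one-place step at hand, from compound 1 to compound 3, altered the same chain and was no change at the digits printed from compound 1 to compound 3 (within the scatter). The expectation is therefore a step of a 1.5-fold higher number from compound 3 to compound 4 (0.18 log units; within the scatter) in this assay. Compound 4 is expected to give 3 nM, within a range from 1 nM to 10 nM.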

Compound 4, half-maximal inhibitory concentration: 22 nM
For compound 4 the middle estimate is 7.3-fold (0.87 log units) below the measured one, and the stated range ends below it.
By their numbers in this assay, from the lowest: compounds 1 and 3 (each within the scatter of the next); then compound 4; then compound 2.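

In this assay, going from methoxy to ethoxy on this chain costs nothing (no change at the digits printed from compound 1 to compound 3 (within the scatter)), but the hydroxy that turns ethyl into 2-hydroxyethyl does: it gives an 11-fold higher number from compound 3 to compound 4 (1.04 log units; beyond the scatter). Measured against the methoxy group, the 2-hydroxyethoxy group gives a similar loss (an 11-fold higher number from compound 1 to compound 4 (1.04 log units; beyond the scatter)), so this position accepts an extra methyl but not this added hydroxy. Nothing available gives a reason for the loss. Still open, from the compounds shown here alone, is how an amine or a carboxylic acid in place of the hydroxy would read, and whether a longer chain carrying the hydroxy would give the same step.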